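Moving the nitro group on a uridine triphosphate analogue

A few compounds are considered here, and "the series" means these few. Any claim that something is new, unique, unknown or untested is made for them only; others in the source may bear on it.

Compound 1, `O=c1[nH]/c(=N\OCCOc2ccccc2)ccn1[C@@H]1O[C@H](COP(=O)(O)OP(=O)(O)OP(=O)(O)O)[C@@H](O)[C@H]1O`: 430 nM
Compound 2, `O=c1[nH]/c(=N\OCCCc2ccc(I)cc2)ccn1[C@@H]1O[C@H](COP(=O)(O)OP(=O)(O)OP(=O)(O)O)[C@@H](O)[C@H]1O`: 91 nM
Compound 3, `O=c1[nH]/c(=N\OCCCc2cccc([N+](=O)[O-])c2)ccn1[C@@H]1O[C@H](COP(=O)(O)OP(=O)(O)OP(=O)(O)O)[C@@H](O)[C@H]1O`: 95 nM

All three share the same core and were tested in a functional assay on 1321-N1 cells for agonist activity at P2Y purinoceptor 4 (Homo sapiens), read by scintillation counting and inositol phosphate accumulation; a higher number here means that more compound is needed for the effect, a lower number that less compound is needed. Compound 3 stands second highest of the three numbers; its nearest neighbour is compound 2, and the two lie within the scatter, as a 1.0-fold higher number from compound 2 to compound 3 (0.02 log units; within the scatter) shows. Compound 1 is the furthest away, with a 4.5-fold lower number from compound 1 to compound 3 (0.66 log units; beyond the scatter).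

Compound 4, `O=c1[nH]/c(=N\OCCCc2ccc([N+](=O)[O-])cc2)ccn1[C@@H]1O[C@H](COP(=O)(O)OP(=O)(O)OP(=O)(O)O)[C@@H](O)[C@H]1O`, has not yet been measured. It differs from compound 3 by 4-nitrophenyl in place of 3-nitrophenyl on a saturated chain carbon, three bonds along the chain from an oxygen. Among the measured compounds shown here, the step that bears on this is the one from compound 2 to compound 3, where one aryl group replaced another at the same position on the chain and the read-out stayed put: a 1.0-fold higher number from compound 2 to compound 3 (0.02 log units; within the scatter). The two larger steps, a 4.7-fold lower number from compound 1 to compound 2 (0.67 log units; beyond the scatter) and a 4.5-fold lower number from compound 1 to compound 3 (0.66 log units; beyond the scatter), concern a different change in the chain and say little about the nitro position. For the measured compounds named here, no measured step directly tests moving a substituent around the aromatic ring.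

Compound 4 is therefore expected to give a number close to compound 3, with a 1.1-fold lower number from compound 3 to compound 4 (0.02 log units; within the scatter) within the scatter. The estimate for compound 4 is 90 nM, ranging from 40 nM to 200 nM.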

Compound 4, half-maximal effective concentration: 84 nM
Compound 4: the middle estimate sits 1.1-fold (0.03 log units) above what was measured; measured number inside the range.
By their numbers in this assay, from the lowest: compounds 4, 2 and 3 (each within the scatter of the next); then compound 1.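

In this assay, among the compounds shown here, moving the nitro group, with 4-nitrophenyl in place of 3-nitrophenyl on the chain, left the read-out level (a 1.1-fold lower number from compound 3 to compound 4 (0.05 log units; within the scatter)), which gives a direct test of substituent position on this aromatic ring that the earlier compounds did not provide. With nitro in place of iodo on an aromatic carbon, the number also held level (a 1.1-fold lower number from compound 2 to compound 4 (0.03 log units; within the scatter)), whereas 4-nitrobenzyl in place of phenoxy gave a step beyond the scatter (a 5.1-fold lower number from compound 1 to compound 4 (0.71 log units; beyond the scatter)). Nothing available here accounts for why the read-out stays level across these aromatic changes.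

Going by these compounds, whether an amine or a carboxylic acid on the aromatic ring would also hold the number level remains open. So does the effect of a longer chain between the oxygen and the nitrophenyl ring.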